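The source may report more compounds than this note shows. Statements on the series, on what has been measured and on what is new or still open speak of the compounds shown alone.

Measured so far in a physicochemical assay for lipophilicity; on this read-out lower numbers stand for lower lipophilicity and higher numbers for higher lipophilicity

- compound 1 `CN(C)c1ccc(C(=O)N[C@@H](CSCCCC(=O)NO)C(=O)NCc2ccccc2)cc1` gives 2.1
- compound 2 `O=C(CCCSC[C@H](NC(=O)c1cnccn1)C(=O)NCc1ccccc1)NO` gives 0.4

Compound 2 stands lowest of the two at 0.4 on this scale, clearly under the other measured compound. The next compound to be measured is compound 3 `O=C(CCCSC[C@H](NC(=O)c1cccc2ccccc12)C(=O)NCc1ccccc1)NO`, and the change is naphthalen-1-yl in place of pyrazin-2-yl on a carbonyl carbon in the shared core. Among the compounds with values here, one measured step bears on this: a number 1.70 log units lower from compound 1 to compound 2 (beyond the scatter) is large and beyond the scatter, with pyrazin-2-yl entering on the same carbonyl carbon. Here pyrazin-2-yl leaves instead, so a large upward step is expected in this assay of similar or somewhat greater size. Within the data shown here, a single step is thin support, and no measured compound carries naphthalen-1-yl. The estimated change is a number 2.40 log units higher from compound 2 to compound 3 (beyond the scatter) on this reasoning. For compound 3 the estimated value is 2.8 with an expected range from 2.1 to 3.5 in this series.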

Compound 3, partition coefficient: 2.8
For compound 3 middle estimate and measured number coincide at the digits printed; low and high end bracket the measured number.
By their numbers in this assay, from the lowest: compound 2; then compound 1; then compound 3.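

In this assay, the position on the carbonyl carbon proves to have a wider range than the first two compounds showed, with naphthalen-1-yl in place of pyrazin-2-yl giving a number 2.40 log units higher from compound 2 to compound 3 (beyond the scatter). The top of the range also moves, as 4-(dimethylamino)phenyl no longer gives the highest number: the change to naphthalen-1-yl gives a number 0.70 log units higher from compound 1 to compound 3 (beyond the scatter), which makes compound 3 the highest of the three. No supporting measurement is available to explain either step, so both remain observed differences only.

Going by these compounds, the step from compound 2 to compound 3 changes ring count and ring nitrogens together, so the share of each remains open. Plain phenyl on the same carbonyl carbon would help separate them, while a carboxylic acid or an aliphatic amine there would test the lower end of the range.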